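The source may report more compounds than this note shows. Statements on the series, on what has been measured and on what is new or still open speak of the compounds shown alone.

In a functional assay on MCF7 cells (Homo sapiens) for antiproliferative activity, read by MTT assay, with a stated time of 48 h (on this read-out higher numbers stand for weaker inhibition and lower numbers for stronger inhibition), three compounds sharing one core have been measured. Compound 1 `CCn1c(C(=O)N(C)CC(=O)O)ccc1C(CC)(CC)c1ccc(OCCC(O)(CC)CC)c(C)c1` gives 79 nM, compound 2 `CCn1c(C(=O)N(C)CCO)ccc1C(CC)(CC)c1ccc(OCCC(O)(CC)CC)c(C)c1` gives 2870 nM, and compound 3 `CCn1c(C(=O)NC(CO)CCO)ccc1C(CC)(CC)c1ccc(OCCC(O)(CC)CC)c(C)c1` gives 31400 nM, the highest of the three numbers and so the weakest inhibition among them. Compound 4 `CCn1c(C(=O)NC(C)CO)ccc1C(CC)(CC)c1ccc(OCCC(O)(CC)CC)c(C)c1` departs from compound 3 by one change, (hydrogen in place of hydroxymethyl on a saturated chain carbon, two bonds along the chain from an amide-type nitrogen). Cut one bond further out, the same difference reads 2-hydroxyethyl to methyl.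

For the measured compounds named here, no measured step makes exactly this change, so the evidence is indirect. Two steps show how far compound 3 lies from the others: a 400-fold higher number from compound 1 to compound 3 (2.60 log units; beyond the scatter) and an 11-fold higher number from compound 2 to compound 3 (1.04 log units; beyond the scatter). Both alter the group on the carbonyl carbon, and both are large, as is a 36-fold higher number from compound 1 to compound 2 (1.56 log units; beyond the scatter). The closer guide is the smaller of the two steps into compound 3, an 11-fold higher number from compound 2 to compound 3 (1.04 log units; beyond the scatter), so a sizeable move toward a lower number is expected in this assay. The expected move is a 7.9-fold lower number from compound 3 to compound 4 (0.89 log units; beyond the scatter). The estimate for compound 4 is 4000 nM, with an expected range of 800 nM to 20000 nM.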

Compound 4, half-maximal inhibitory concentration: 12600 nM
Compound 4: the middle estimate sits 3.2-fold (0.50 log units) below what was measured; the range from low to high includes it.
By their numbers in this assay, from the lowest: compound 1; then compound 2; then compound 4; then compound 3.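

In this assay, for the compounds shown here, hydrogen in place of hydroxymethyl on this saturated chain carbon, two bonds along the chain from an amide-type nitrogen, is the first change at this position that can be read alone, and it gives a 2.5-fold lower number from compound 3 to compound 4 (0.40 log units; beyond the scatter). The change closes only part of the gap to the other compounds, with a 4.4-fold higher number from compound 2 to compound 4 (0.64 log units; beyond the scatter) and, much larger, a 160-fold higher number from compound 1 to compound 4 (2.20 log units; beyond the scatter), so the group on the carbonyl carbon still matters well beyond this one hydroxymethyl. No supporting evidence accounts for the size of these steps. Going by these compounds, what remains open is how an amine, a carboxylic acid or a longer chain at this same carbon would compare with hydrogen and hydroxymethyl. Also open, on these data alone, is whether a carboxylic acid in place of the hydroxyl of the 1-(hydroxymethyl)ethyl group would bring the number down.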